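The compounds below may be only part of what the source reports. "The series", "measured", "known", "first", "only" and "open" are said of these compounds alone.

Compound 1 `O=[N+]([O-])c1ccc(CN2CCC(n3cc(CC(OCc4cc(-c5ccccc5)no4)c4ccc(Br)cc4)nn3)CC2)cc1` sits at a limit of a functional assay on PC-3 cells (Homo sapiens) for cytotoxicity, with a stated time of 48 h (on this read-out lower numbers stand for stronger inhibition and higher numbers for weaker inhibition), giving > 25000 nM. Compound 2 `O=[N+]([O-])c1ccc(CN2CCC(n3cc(CC(OCc4cc(-c5cccc(Br)c5)no4)c4ccc(Br)cc4)nn3)CC2)cc1`, which differs by a step that the two limits leave unreadable from compound 1 to compound 2, also sits at the limit, with > 25000 nM. Among the measured compounds shown here, compound 3 `O=[N+]([O-])c1ccc(CN2CCC(n3cc(CC(OCc4cc(-c5cccc(F)c5)no4)c4ccc(Br)cc4)nn3)CC2)cc1` is the only member of the set with a number in this assay, where compound 3 gives 9000 nM. Against compound 1 that is an at least 2.7-fold lower number from compound 1 to compound 3 (0.44 log units; beyond the scatter), and against compound 2 it is an at least 2.7-fold lower number from compound 2 to compound 3 (0.44 log units; beyond the scatter), though both steps rest on (the limit of > 25000 nM in this assay, at which 2 of the 3 values shown sit), so their true sizes remain open.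

Compound 4 `COc1cccc(-c2cc(COC(Cc3cn(C4CCN(Cc5ccc([N+](=O)[O-])cc5)CC4)nn3)c3ccc(Br)cc3)on2)c1` differs from compound 3 by methoxy in place of fluoro on an aromatic carbon. Of the measured steps, the one that bears most closely on this change is the exchange of bromo for fluoro, read as an at least 2.7-fold lower number from compound 2 to compound 3 (0.44 log units; beyond the scatter): the compound carrying the heavier group on that ring sat at the limit, and the compound carrying fluoro gave a number. Methoxy, like bromo, is a bulkier substituent than fluoro, so compound 4 is expected to drift back towards the limit rather than to improve, with a step estimated at a 2.2-fold higher number from compound 3 to compound 4 (0.35 log units; beyond the scatter). For compound 4 the expected value in this assay is 20000 nM, within a range from 8000 nM to 40000 nM.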

Compound 4, half-maximal inhibitory concentration: > 25000 nM
Compound 4: only a limit was reported (the forecaster's own chance of this, stated with the estimate: 40%); middle value at least 1.2-fold (0.09 log units) away from the limit.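

Exchanging fluoro for methoxy at this place on the ring gives an at least 2.7-fold higher number from compound 3 to compound 4 (0.44 log units; beyond the scatter) in this assay. Earlier, only hydrogen and bromo had been set against fluoro here; methoxy, with its oxygen and one hydrogen-bond acceptor, now joins them, so that among the four groups shown, only the fluoro of compound 3 yields a number rather than a limit. The steps joining compound 1 and compound 2 to compound 4 cannot be read, and the step from fluoro to methoxy is bounded on one side only: the limit of > 25000 nM in this assay, at which 3 of the 4 values shown sit.

The compounds shown leave open whether compound 1, compound 2 and compound 4 differ from one another at all, and thus whether hydrogen, bromo and methoxy can be ranked at this place. They also leave open whether the number belongs to fluoro alone or would also appear with another group on this aromatic carbon, such as chloro, hydroxy, an amine or a nitrile.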